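Methyl for methoxy on the fused ring of compound 3

This account rests on a few compounds, and the source may have more. Where it says the series, first, only, none or still open, it means among the compounds named here.

Of the compounds shown here, three have been measured in a functional assay on MCF7 cells (Homo sapiens) for antiproliferative activity, read by fluorescence and SYBR Green assay, with a stated time of 24 h; a higher number here means a weaker inhibitor, a lower number a stronger inhibitor. Compound 1 `CCCN(c1ccccc1)S(=O)(=O)c1ccc(N2CCCC2=O)cc1` gives > 5000 nM, which is a limit of the assay and not a number. The value of compound 1 is the one sitting at the limit of > 5000 nM in this assay, at which 1 of the 3 values shown sits. Compound 2 `CN1CCN(S(=O)(=O)c2ccc(N3CCCC3=O)cc2)c2ccccc21` gives 10 nM in this assay. Compound 3 `COc1ccc2c(c1)CCCN2S(=O)(=O)c1ccc(N2CCCC2=O)cc1` gives 25 nM in this assay, the higher of the two numbers shown, and its gap to compound 2 lies beyond the usual scatter. For the measured compounds named here, no step between two measured compounds differing in one place is available, so the effect of any single change on this read-out remains untested.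

Compound 4 `Cc1ccc2c(c1)CCCN2S(=O)(=O)c1ccc(N2CCCC2=O)cc1` differs from compound 3 by methyl in place of methoxy on an aromatic carbon. The shared core and the sulfonyl-linked portion are otherwise unchanged. Going by the values given here, since the two measured numbers come from cores that differ in more than this one place, no measured step gives guidance on this change. The step from compound 3 to compound 4 is expected to be small, a 1.4-fold higher number from compound 3 to compound 4 (0.15 log units; within the scatter), not beyond the scatter in either direction. Compound 4 is therefore estimated at 35 nM in this assay, with a range from 12 nM to 100 nM.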

Compound 4, half-maximal inhibitory concentration: 15 nM
Beside the measured number, compound 4's estimate is 2.3-fold (0.37 log units) above it, and the stated range covers the measured number.
By their numbers in this assay, from the lowest: compounds 2, 4 and 3 (each within the scatter of the next, the first and the last beyond it). At a limit, above all of these: compound 1.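

The series now has its first step that changes one place only, on an aromatic carbon of the fused system: methyl in place of methoxy gives a 1.7-fold lower number from compound 3 to compound 4 (0.22 log units; within the scatter) in this assay. At this position, then, the low-nanomolar read-out does not depend on the methoxy group, since a group without its oxygen and without its hydrogen-bond acceptor gives a number within the scatter. No measured property in the data bears on this step, and the read-out alone gives no reason for it.

Open at this aromatic carbon is what plain hydrogen would give, and with it whether either methyl or methoxy adds anything to the read-out or merely sits there without effect. Also open, as far as these compounds go, is how far the position extends beyond these two small groups, for example to a chlorine, an amine, a carboxylic acid or a longer chain such as butyl, any of which would test the position more sharply than this pair can.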